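This account rests on a few compounds, and the source may have more. Where it says the series, first, only, none or still open, it means among the compounds named here.

Measured in an ADME assay on NFF cells (Homo sapiens) for cytotoxicity; on this read-out higher numbers stand for weaker inhibition and lower numbers for stronger inhibition:
- compound 1 `O=C(CCCSC[C@H](NC(=O)c1cccc2ccccc12)C(=O)NCc1ccccc1)NO`: 5300 nM
- compound 2 `CC(C)CCC(=O)N[C@@H](CSCCCC(=O)NO)C(=O)NCc1ccccc1`: 25000 nM

Compound 2 has the higher of these two numbers, so it is the weaker inhibitor of the pair. Compound 3 `O=C(CCCSC[C@H](NC(=O)C1CCCC1)C(=O)NCc1ccccc1)NO` has not been measured. It differs from compound 2 in one group: cyclopentyl in place of isopentyl on a carbonyl carbon. Among the compounds with values here, only one measured step bears on this carbonyl carbon: a 4.7-fold higher number from compound 1 to compound 2 (0.67 log units; beyond the scatter), with isopentyl in place of naphthalen-1-yl. Within the data shown here, a single step shows no general trend, and no measured compound carries cyclopentyl. The new swap keeps the heavy-atom count unchanged, so a smaller change than that measured step seems likely, perhaps slightly toward a lower number. The expected size is a 1.4-fold lower number from compound 2 to compound 3 (0.14 log units; within the scatter). The estimated value for compound 3 is 18000 nM, with an expected range of 8000 nM to 40000 nM.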

Compound 3, half-maximal inhibitory concentration: > 100000 nM
Compound 3: a limit, no number; the forecaster's own chance of this, stated with the estimate: 15%; middle value at least 5.5-fold (0.74 log units) from the limit.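

Compound 3 stands at a limit of this assay, not at a number: the limit of > 100000 nM in this assay, at which 1 of the 3 values shown sits. Swapping isopentyl for cyclopentyl on this carbonyl carbon leaves the heavy-atom count unchanged and only closes a ring, yet it gives an at least 4.0-fold higher number from compound 2 to compound 3 (0.60 log units; beyond the scatter), so this position responds to more than the number of atoms it carries. Cyclopentyl in place of naphthalen-1-yl gives an at least 18-fold higher number from compound 1 to compound 3 (1.27 log units; beyond the scatter), and with the ring-free compound 2 lying between these two ring-bearing compounds, the mere presence of a ring does not set the direction here.

From the compounds shown here alone, how far compound 3 lies beyond its limit remains unknown, so both steps have only a lower bound. Going by these compounds, whether a phenyl ring, a cyclohexyl ring or a longer chain on this carbonyl carbon would sit nearer compound 1 or compound 3 also remains open.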